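The compounds below may be only part of what the source reports. "The series", "measured", "known", "first", "only" and "open" are said of these compounds alone.

Measured compounds:
compound 1, `CN(C)CCn1c(=O)sc2cc(S(=O)(=O)Nc3ccccc3)ccc21`, 21%
compound 2, `O=c1sc2cc(S(=O)(=O)Nc3ccccc3)ccc2n1CCN1CCCCC1`, 7%

Both were run in an assay on HEK293 cells for displacement of a labelled ligand from 5-hydroxytryptamine receptor 6 (Homo sapiens), read by radioligand binding, with a stated time of 60 min, tested at 100 nM; a higher number here means more inhibition at the concentration tested (going by the name of the read-out), a lower number less inhibition. Going by the values given here, compound 2 stands lowest of the two numbers; its nearest neighbour is compound 1, and the only measured step, a number 14 percentage points lower from compound 1 to compound 2 (beyond the scatter), goes beyond the scatter and is modest in size. That step changes the amine on the saturated chain and leaves the sulfonamide untouched.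

Compound 3 is `O=c1sc2cc(S(=O)(=O)Nc3cccc4ccccc34)ccc2n1CCN1CCCCC1`, not yet measured. Its difference from compound 2 is naphthalen-1-yl in place of phenyl on a sulfonamide nitrogen. No measured step touches the sulfonamide nitrogen or the aryl group on it, so nothing shown bears directly on this change; the one step that is shown concerns a different part of the structure. Compound 2 sits near the bottom of the scale, which leaves little room to fall further and more room to rise, but no shown number points to either direction.

For compound 3 the estimated value is 15%, within 0% to 45%. The step this implies, a number 8 percentage points higher from compound 2 to compound 3 (within the scatter), is expected to stay within the scatter.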

Compound 3, a percentage reported as inhibition, at one concentration (the size of the read-out at that concentration, not a potency): 3%
Beside the measured number, compound 3's estimate is 12 percentage points above it, and the stated range covers the measured number.
By their numbers in this assay, from the lowest: compounds 3 and 2 (each within the scatter of the next); then compound 1.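

The aryl group on the sulfonamide nitrogen now has its first reading: in this assay the exchange gives a number 4 percentage points lower from compound 2 to compound 3 (within the scatter) and so shows no step beyond the scatter when naphthalen-1-yl, with its second six-membered aromatic ring of carbon only, replaces phenyl. With the piperidin-1-yl chain held constant, the added ring brings no measurable rise in inhibition at the concentration tested, and since both numbers lie at the low end of the scale, a further fall would be hard to resolve from this pair. Nothing measured here speaks to the reason for this outcome.

As far as these compounds go, whether naphthalen-1-yl on the sulfonamide nitrogen reads the same with the dimethylamino chain of compound 1, where the scale leaves more room for a fall, remains open. Also open, from the compounds shown here alone, is how this position responds to groups such as naphthalen-2-yl, a pyridine ring or a benzyl group, or to a methyl group replacing the hydrogen on the sulfonamide nitrogen.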